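This account rests on a few compounds, and the source may have more. Where it says the series, first, only, none or still open, it means among the compounds named here.

Measured so far in a functional assay on SGC-7901 cells (Homo sapiens) for cytotoxicity, read by MTT assay, with a stated time of 72 h; a higher number here means a weaker inhibitor, a lower number a stronger inhibitor:

Compound 1 `O=C(Nc1ccc(-n2ncc3c(Cl)cccc32)cc1)Nc1ccc(Cl)c(C(F)(F)F)c1` gives 4600 nM.
Compound 2 `O=C(Nc1ccc(-n2ncc3c(Br)cccc32)cc1)Nc1ccc(Cl)c(C(F)(F)F)c1` gives 16600 nM.
Compound 3 `CNc1cccc2c1cnn2-c1ccc(NC(=O)Nc2ccc(Cl)c(C(F)(F)F)c2)cc1` gives 6900 nM.

These three share one core and differ only in the group carried on one aromatic carbon of the fused ring system. Compound 3, which carries a methylamino group there, has the second highest of the three numbers. The step of a 1.5-fold higher number from compound 1 to compound 3 (0.18 log units; within the scatter) lies within the scatter, so compound 1 and compound 3 cannot be told apart on these numbers. The step of a 2.4-fold lower number from compound 2 to compound 3 (0.38 log units; beyond the scatter) is beyond the scatter, as is the step of a 3.6-fold higher number from compound 1 to compound 2 (0.56 log units; beyond the scatter).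

Compound 4 `COc1cccc2c1cnn2-c1ccc(NC(=O)Nc2ccc(Cl)c(C(F)(F)F)c2)cc1` is the next change at the same place: methoxy in place of methylamino on an aromatic carbon. The three measured steps all exchange a small group on this carbon, and the largest of them is only modest; two of them are within or barely beyond the scatter. A change from methylamino to methoxy, a group of the same size that keeps one acceptor and drops the donor, is therefore expected to move the number little, with no clear direction. The expected step of a 1.1-fold higher number from compound 3 to compound 4 (0.04 log units; within the scatter) is small. Compound 4 is estimated at 7500 nM, within a range from 3000 nM to 18000 nM.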

Compound 4, half-maximal inhibitory concentration: 29800 nM
Beside the measured number, compound 4's estimate is 4.0-fold (0.60 log units) below it; the measured number lies above the stated range.
By their numbers in this assay, from the lowest: compounds 1 and 3 (each within the scatter of the next); then compounds 2 and 4 (each within the scatter of the next).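

In this assay, methoxy in place of methylamino gives a 4.3-fold higher number from compound 3 to compound 4 (0.64 log units; beyond the scatter), so this carbon can separate two groups with the same count of heavy atoms, a contrast the earlier exchanges of chloro, bromo and methylamino did not offer. Methoxy also stands apart from chloro, with a 6.5-fold higher number from compound 1 to compound 4 (0.81 log units; beyond the scatter), whereas a 1.8-fold higher number from compound 2 to compound 4 (0.25 log units; within the scatter) means that compound 2 and compound 4 cannot be told apart, so the four compounds fall into two pairs: chloro with methylamino, and bromo with methoxy. The hydrogen-bond donor present in methylamino and absent from methoxy is a difference counted between the two structures, and no measurement at hand explains the split.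

The compounds shown leave open whether the nitrogen of methylamino or its hydrogen goes with the lower number of compound 3, a question that dimethylamino and hydroxy groups on this carbon could help to separate. Also open, from the compounds shown here alone, is how a fluoro group, a plain amine or a longer chain such as ethylamino would compare here, and whether any group at this carbon can give a number clearly lower than that of compound 1.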